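The compounds below may be only part of what the source reports. "The series", "measured", "known", "first", "only" and "open" are said of these compounds alone.

Measured so far:
Compound 1, `CCn1c(C(=O)NCCC(=O)OC)ccc1C(CC)(CC)c1ccc(OCS(=O)(=O)c2ccccc2)c(C)c1`, which in a functional assay on PC-3 cells (Homo sapiens) for antiproliferative activity, read by MTT assay, with a stated time of 24 h (on this read-out lower numbers stand for stronger inhibition and higher numbers for weaker inhibition), gives 40400 nM.
Compound 2, `CCn1c(C(=O)N[C@@H](CO)CCCO)ccc1C(CC)(CC)c1ccc(OCS(=O)(=O)c2ccccc2)c(C)c1`, which in this assay gives 13400 nM.

Of these two compounds, compound 2 stands at the lowest number in this assay, and its nearest neighbour is compound 1. Going by the values given here, the only measured step is a 3.0-fold lower number from compound 1 to compound 2 (0.48 log units; beyond the scatter), and it lies on the amide-type nitrogen of the shared core.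

Compound 3, `CCn1c(C(=O)N[C@@H](CCC(=O)O)C(=O)O)ccc1C(CC)(CC)c1ccc(OCS(=O)(=O)c2ccccc2)c(C)c1`, has not yet been measured. It differs from compound 2 in one place:
a group of 9 heavy atoms (5 carbon, 4 oxygen; no ring) in place of a group of 7 heavy atoms (5 carbon, 2 oxygen; no ring), on an amide-type nitrogen

Among the compounds with values here, the one step that bears on this change is a 3.0-fold lower number from compound 1 to compound 2 (0.48 log units; beyond the scatter), since it also swaps the group on the amide-type nitrogen, and it was modest. Within the data shown here, no measured compound carries a 1,3-dicarboxypropyl group, so nothing shows how that particular group behaves in this assay. Among the measured compounds shown here, with a single modest step as the only guide, compound 3 is expected to remain close to compound 2, with a step of a 1.3-fold higher number from compound 2 to compound 3 (0.13 log units; within the scatter) that stays within or only slightly beyond the scatter. Compound 3 is therefore estimated at 18000 nM, within a range from 5000 nM to 60000 nM.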

Compound 3, half-maximal inhibitory concentration: > 50000 nM
Compound 3: a limit, no number; the forecaster's own chance of this, stated with the estimate: 10%; middle value at least 2.7-fold (0.44 log units) from the limit.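

In this assay compound 3 gives > 50000 nM, a limit of the assay and not a number, and it is the only compound shown to sit there: the limit of > 50000 nM in this assay, at which 1 of the 3 values shown sits. The group on the amide-type nitrogen can thus move the number upward as well as downward: putting 1,3-dicarboxypropyl in place of the group of compound 2 gives an at least 3.7-fold higher number from compound 2 to compound 3 (0.57 log units; beyond the scatter), whereas the earlier step, a 3.0-fold lower number from compound 1 to compound 2 (0.48 log units; beyond the scatter), ran the other way. The comparison with compound 1 adds nothing firm, as the step of an at least 1.2-fold higher number from compound 1 to compound 3 (0.09 log units; that floor lies within the scatter) is only a floor and cannot be read as a real difference.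

The limit leaves open how far the true value of compound 3 lies from that of compound 2, and the compounds shown do not tell which part of the 1,3-dicarboxypropyl group matters for the change. A chain with a single carboxylic acid, the dimethyl ester of the same group, or a primary amine on the amide-type nitrogen would be needed to separate these possibilities.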